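Swapping 2-fluorophenyl for (2-chlorophenyl)carbonyl in compound 2

The source may hold more compounds than are shown below. What is called first, only, known or untested is meant among the compounds shown, and "the series" means these compounds.

In a functional assay on SGC-7901 cells (Homo sapiens) for antiproliferative activity, read by MTT assay, with a stated time of 24 h (on this read-out lower numbers stand for stronger inhibition and higher numbers for weaker inhibition), compound 1 `Cc1cccc(NNC(=O)c2ccc(NS(=O)(=O)c3cnc(O)nc3O)cc2)c1` gives > 20000 nM, which is a limit and not a number. Compound 3 `O=C(NNc1ccc(F)cc1)c1ccccc1NS(=O)(=O)c1cnc(O)nc1O` gives > 20000 nM, also a limit. For the measured compounds named here, compound 2 `O=C(NNc1ccccc1F)c1ccc(NS(=O)(=O)c2cnc(O)nc2O)cc1` gives 16000 nM, the only actual number among the three. Compound 4 `O=C(NNC(=O)c1ccccc1Cl)c1ccc(NS(=O)(=O)c2cnc(O)nc2O)cc1` has (2-chlorophenyl)carbonyl in place of 2-fluorophenyl on an amine nitrogen. Going by the values given here, the only measured step that bears on this position is an at least 1.2-fold lower number from compound 1 to compound 2 (0.09 log units; that floor lies within the scatter), and it offers no sign of a real gain. The estimate must also reckon with the limit of > 20000 nM in this assay, at which 2 of the 3 values shown sit. No step beyond the scatter is therefore expected in this assay, and the expected change is a 1.1-fold lower number from compound 2 to compound 4 (0.03 log units; within the scatter). For compound 4 the estimated value is 15000 nM, with an expected range from 6000 nM to 20000 nM.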

Compound 4, half-maximal inhibitory concentration: 3240 nM
Estimate against measurement, compound 4: 4.6-fold (0.67 log units) above; measured number below the stated range.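

Putting (2-chlorophenyl)carbonyl on this amine nitrogen gives, in this assay, a 4.9-fold lower number from compound 2 to compound 4 (0.69 log units; beyond the scatter), so this position can shift the read-out beyond the scatter, which the earlier step within the scatter had not shown. Against 3-methylphenyl, the same group gives an at least 6.1-fold lower number from compound 1 to compound 4 (0.79 log units; beyond the scatter). That step is only a floor, as compound 1 stands at a limit: the limit of > 20000 nM in this assay, at which 2 of the 4 values shown sit.

The change brings in a carbonyl and replaces fluorine with chlorine at once, and the compounds shown do not separate the two. Going by these compounds, whether (2-fluorophenyl)carbonyl or a plain acetyl group on this nitrogen would keep the gain stays open.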